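The source may report more compounds than this note shows. Statements on the series, on what has been measured and on what is new or still open speak of the compounds shown alone.

Compound 1 `COc1cc(-c2ccnc3cc(-c4ccc(C(C)=O)cc4)nn23)cc(OC)c1OC`, compound 2 `COc1cc(-c2ccnc3cc(-c4ccc(N(C)C)cc4)nn23)cc(OC)c1OC` and compound 3 `COc1ccc(-c2cc3nccc(-c4cc(OC)c(OC)c(OC)c4)n3n2)cc1` share one core and differ only in the group on the outer phenyl ring. In a functional assay on B16-F0 cells (Mus musculus) for inhibition, read by CCK-8 assay, with a stated time of 48 h (a lower number here means a stronger inhibitor, a higher number a weaker inhibitor), compound 1 gives 3930 nM, compound 2 gives 702 nM, and compound 3 gives 1410 nM, the second highest of the three numbers. The two changes at this ring were a 2.8-fold lower number from compound 1 to compound 3 (0.45 log units; beyond the scatter) and a 2.0-fold higher number from compound 2 to compound 3 (0.30 log units; within the scatter). Compound 4 `COc1cc(-c2ccnc3cc(-c4ccc(C)c(C)c4)nn23)cc(OC)c1OC` carries a different group at the same place: 3,4-dimethylphenyl in place of 4-methoxyphenyl on an aromatic carbon. Among the measured compounds shown here, no measured step swaps methoxy for methyl groups, so the step of compound 3 to compound 4 in this assay is uncertain; because the changes seen there were at most a 5.6-fold lower number from compound 1 to compound 2 (0.75 log units; beyond the scatter), a small shift is expected, and compound 4 is estimated at 1500 nM, expected within 600 nM to 4000 nM, an expected step of a 1.1-fold higher number from compound 3 to compound 4 (0.03 log units; within the scatter).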

Compound 4, half-maximal inhibitory concentration: 391 nM
Compound 4: middle estimate off by 3.8-fold (0.58 log units), on the high side; measured number outside the range, below it.
By their numbers in this assay, from the lowest: compounds 4, 2 and 3 (each within the scatter of the next, the first and the last beyond it); then compound 1.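

In this assay the outer ring needs no oxygen or nitrogen on it: 3,4-dimethylphenyl, which has no hydrogen-bond acceptor, gives a 3.6-fold lower number from compound 3 to compound 4 (0.56 log units; beyond the scatter) and a 10-fold lower number from compound 1 to compound 4 (1.00 log units; beyond the scatter). Against the dimethylamino group the change gives a 1.8-fold lower number from compound 2 to compound 4 (0.25 log units; within the scatter), which lies within the scatter, so these two compounds cannot be ranked. Nothing measured here explains these steps. On these data alone, the change from compound 3 to compound 4 removes a methoxy group and adds two methyl groups at once, so the share of each methyl group stays open. As far as these compounds go, how a single methyl group, a chlorine atom or a primary amine on this ring would compare also stays open.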